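The source may hold more compounds than are shown below. What is called first, only, known or untested is meant among the compounds shown, and "the series" means these compounds.

Compound 1, with the structure `CCCCCCCCc1cc(-c2cn([C@H]3C[C@H](O)[C@@H](CO)O3)c(=O)[nH]c2=O)on1`, belongs to a small set of three compounds tested in a functional assay on ACHN cells (Homo sapiens) for cytotoxicity, read by sulforhodamine B assay, tested at 10 uM; on this read-out higher numbers stand for more inhibition at the one concentration tested (going by the name of the read-out) and lower numbers for less inhibition. In this assay compound 1 gives 95.6%. Compound 2, with the structure `O=c1[nH]c(=O)n([C@H]2C[C@H](O)[C@@H](CO)O2)cc1-c1cn(Cc2ccccc2)nn1`, gives 98.7% in this assay, and compound 3, with the structure `CCCCCc1cc(-c2cn([C@H]3C[C@H](OC(C)=O)[C@@H](COC(C)=O)O3)c(=O)[nH]c2=O)on1`, gives 99.8%. The number for compound 1 is the smallest of the three, yet the gap to compound 2 and the gap to compound 3 each lie within the usual scatter, so the three readings cannot be told apart.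

Compound 4, with the structure `CC(C)(C)c1ccc(-c2cc(-c3cn([C@H]4C[C@H](O)[C@@H](CO)O4)c(=O)[nH]c3=O)on2)cc1`, has not yet been measured. It differs from compound 1 in one place: 4-(tert-butyl)phenyl in place of octyl on an aromatic carbon. Going by the values given here, no pair of measured compounds differs in a single place, so there is no measured step to lean on. Because compound 1 gives 95.6% and the other two measured compounds give numbers within the scatter of it, the expected step is a number 2.6 percentage points lower from compound 1 to compound 4 (within the scatter), none beyond the scatter. Compound 4 is therefore expected to give about 93%, likely between 75% and 100%.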

Compound 4, a percentage reported as inhibition, at one concentration (the size of the read-out at that concentration, not a potency): 94.2%
Compound 4: the middle estimate sits 1.2 percentage points below what was measured; low and high end bracket the measured number.
By their numbers in this assay, from the lowest: compounds 4, 1, 2 and 3 (each within the scatter of the next).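

In this assay, the step is a number 1.4 percentage points lower from compound 1 to compound 4 (within the scatter), when 4-(tert-butyl)phenyl replaces octyl on the aromatic carbon next to the ring nitrogen. This position therefore carries either a flexible chain with no ring or a larger group with a six-membered aromatic ring, and the reading cannot tell the two compounds apart. Nothing available explains why the two groups read alike.

From the compounds shown here alone, whether a short group such as methyl, or an amine or a carboxylic acid, would give a different reading at this position remains open. Going by these compounds, each reading also comes from a single concentration, so how compound 1 and compound 4 compare in potency across a range of concentrations remains unknown.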